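This account rests on a few compounds, and the source may have more. Where it says the series, first, only, none or still open, it means among the compounds named here.

Of the compounds shown here, two built on the same core have been tested in an ADME assay on Huh-7 cells (Homo sapiens) for cytotoxicity, read by a luciferase reporter and WST assay, with a stated time of 3 days; on this read-out higher numbers stand for lower toxicity in this test and lower numbers for higher toxicity in this test. Compound 1 `COc1ccc(-c2cc(NO)c(C(=O)Nc3ccc(C)cc3)c(=O)o2)cc1` carries a methoxy group and an amide to a methyl-bearing aromatic group. In this assay compound 1 gives > 20000 nM, which is a limit of the test rather than a number. Compound 2 `O=C(NCCO)c1c(NO)cc(-c2ccc(Cl)cc2)oc1=O` carries a chloro group and an amide to a short chain. In this assay compound 2 gives > 20000 nM, again a limit rather than a measured number. Among the compounds with values here, compound 2 therefore stands exactly where compound 1 stands: both values sit at the limit of > 20000 nM in this assay, at which 2 of the 2 values shown sit, and no step between them can be sized or given a direction. Compound 3 `COc1ccc(-c2cc(NO)c(C(=O)NCCO)c(=O)o2)cc1` differs from compound 2 in one place: methoxy in place of chloro on an aromatic carbon. Within the data shown here, no measured step shows how this change acts in this assay. With both known values at the limit, compound 3 is expected to remain at that limit as well. The step that the limit leaves unreadable from compound 2 to compound 3 is expected to be none beyond the scatter. The estimate for compound 3 is 30000 nM, with a range from 15000 nM to 80000 nM.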

Compound 3, half-maximal cytotoxic concentration: > 20000 nM
Compound 3: only a limit was reported (the forecaster's own chance of this, stated with the estimate: 85%); the middle value does not contradict the limit.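

In this assay compound 3 gives > 20000 nM as a limit and not a number. Its steps from compound 1 and compound 2 therefore cannot be read, since all three compounds share that limit: (the limit of > 20000 nM in this assay, at which 3 of the 3 values shown sit). Still open, on these data alone, is whether, in this assay, swapping chloro for methoxy or 4-methylphenyl for 2-hydroxyethyl changes the result at all.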